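The compounds below may be only part of what the source reports. "The series", "measured", "known", "first", "only" and "open" are said of these compounds alone.

Measured so far in an assay on CHO-K1 cells for inhibition of 11-beta-hydroxysteroid dehydrogenase type 2 (Mus musculus), read by scintillation proximity assay; a higher number here means a weaker inhibitor, a lower number a stronger inhibitor:
compound 1, `CC(C)S(=O)(=O)CCC12CCC(c3nnc(-c4ccccc4C(F)(F)F)n3C)(CC1)CC2`, a limit only: > 4000 nM
compound 2, `CC(O)CCCC12CCC(c3nnc(-c4ccccc4C(F)(F)F)n3C)(CC1)CC2`, a limit only: > 4000 nM
compound 3, `CCCCCC12CCC(c3nnc(-c4ccccc4C(F)(F)F)n3C)(CC1)CC2`, a limit only: > 4000 nM

Compound 3 stands on a limit of this assay and not on a number, as do the two other compounds shown, so no order among the three can be read. The steps a step that the two limits leave unreadable from compound 1 to compound 3 and a step that the two limits leave unreadable from compound 2 to compound 3 both end at compound 3, and a step that the two limits leave unreadable from compound 1 to compound 2 runs between the other two; none of them has a readable size because of the limit of > 4000 nM in this assay, at which 3 of the 3 values shown sit.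

Compound 4, `Cn1c(-c2ccccc2C(F)(F)F)nnc1C12CCC(CCS(=O)(=O)C(C)(C)C)(CC1)CC2`, is the next candidate for this assay. It differs from compound 3 thus: (tert-butyl)sulfonyl in place of propyl on a saturated chain carbon, two bonds along the chain from a saturated ring carbon. The nearest comparison is compound 1, which carries isopropylsulfonyl at the same place and sits only at the limit. Compound 3, with propyl, also sits only at the limit. Nothing measured points to a readable gain or loss, and the step is expected to leave compound 4 at the limit as well: a step that the limit leaves unreadable from compound 3 to compound 4. The estimate for compound 4 in this assay is 8000 nM, within 3000 nM to 30000 nM.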

Compound 4, half-maximal inhibitory concentration: > 4000 nM
Compound 4 was reported as a limit; the forecaster's own chance of this, stated with the estimate: 85%; the middle value is on the limit's open side.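

Compound 4 sits at a limit in this assay, as do compound 1, compound 2 and compound 3, so no step from any of these to compound 4 can be read: the limit of > 4000 nM in this assay, at which 4 of the 4 values shown sit.

The compounds shown leave open how the four rank in this assay, and whether any group at this place on the chain gives a readable value.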